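The source may report more compounds than this note shows. Statements on the series, on what has been measured and on what is new or still open speak of the compounds shown alone.

Measured in a functional assay on DU-145 cells (Homo sapiens) for inhibition, read by trypan blue exclusion, with a stated time of 96 h; on this read-out lower numbers stand for stronger inhibition of growth and higher numbers for weaker inhibition of growth:
- compound 1 `O=C(/C(=C\c1ccc([N+](=O)[O-])c(O)c1)SCc1ccc(Br)cc1)c1ccc(C(F)(F)F)cc1` gives 1000 nM
- compound 2 `O=C(/C(=C\c1ccc(O)c([N+](=O)[O-])c1)SCc1ccc(Br)cc1)c1ccc(Cl)cc1Cl` gives 10000 nM
- compound 3 `N#Cc1ccc(C(=O)/C(=C\c2ccc(O)c([N+](=O)[O-])c2)SCc2ccc(Br)cc2)cc1` gives 10000 nM

Compound 3 stands level with compound 2, and together they hold the highest of the three numbers. Compound 1 lies lower, beyond the scatter. The next compound, compound 4 `O=C(/C(=C\c1ccc(O)c([N+](=O)[O-])c1)SCc1ccc(Br)cc1)c1ccc(C(F)(F)F)cc1`, takes trifluoromethyl in place of cyano on an aromatic carbon, para to a large group: trifluoromethyl in place of cyano on an aromatic carbon. Among the compounds with values here, the only measured step that touches this aromatic group is no change at the digits printed from compound 2 to compound 3 (within the scatter), where 4-cyanophenyl replaces 2,4-dichlorophenyl on a carbonyl carbon. Within the data shown here, compound 1 also carries trifluoromethyl and gives 1000 nM, yet no measured step isolates that group. This offers only a weak hint toward a lower number. The expected change in this assay is therefore small, most likely within the scatter, and if anything toward a lower number: a 1.7-fold lower number from compound 3 to compound 4 (0.22 log units; within the scatter). Compound 4 is estimated at 6000 nM, with an expected range of 1500 nM to 20000 nM.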

Compound 4, concentration for 50% growth inhibition: 10000 nM
For compound 4 the middle estimate is 1.7-fold (0.22 log units) below the measured one; the range from low to high includes it.
By their numbers in this assay, from the lowest: compound 1; then compounds 2, 3 and 4 (each within the scatter of the next).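

In this assay, trifluoromethyl in place of cyano on an aromatic carbon, para to a large group, gives no change at the digits printed from compound 3 to compound 4 (within the scatter), and 4-(trifluoromethyl)phenyl in place of 2,4-dichlorophenyl on a carbonyl carbon gives no change at the digits printed from compound 2 to compound 4 (within the scatter), so these three aromatic groups on the carbonyl carbon cannot be told apart in this series. Placing 4-hydroxy-3-nitrophenyl where 3-hydroxy-4-nitrophenyl stood gives a 10-fold higher number from compound 1 to compound 4 (1.00 log units; beyond the scatter), which shows that trifluoromethyl alone does not go with the lower number of compound 1, and that the gap follows the hydroxy and nitro arrangement. Nothing at hand bears on a cause for either result.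

From the compounds shown here alone, whether 3-hydroxy-4-nitrophenyl gives the same lower number alongside 4-cyanophenyl or 2,4-dichlorophenyl remains open. Also open, going by these compounds, is how an amine or a carboxylic acid on that aromatic carbon would read in this assay.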